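Changing the benzyl group on a shared core

This account rests on a few compounds, and the source may have more. Where it says the series, first, only, none or still open, it means among the compounds named here.

Measured so far:
- compound 1, `O=C(NCc1cn(Cc2ccc(F)cc2)nn1)c1cn(-c2ccccc2)nc1-c1ccc(F)cc1`: 14300 nM
- compound 2, `O=C(NCc1cn(Cc2ccc(C(F)(F)F)cc2)nn1)c1cn(-c2ccccc2)nc1-c1ccc(F)cc1`: 760 nM

Within the data shown here, in a functional assay on MIA PaCa-2 cells (Homo sapiens) for antiproliferative activity, read by sulforhodamine B assay, with a stated time of 48 h (on this read-out higher numbers stand for weaker inhibition of growth and lower numbers for stronger inhibition of growth), compound 2 gives the lower of the two numbers measured so far, with compound 1 as the only neighbour. Among the measured compounds shown here, the one measured step, a 19-fold lower number from compound 1 to compound 2 (1.27 log units; beyond the scatter), shows that the group on the benzyl ring matters a great deal on this core.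

Compound 3, `COc1ccc(Cn2cc(CNC(=O)c3cn(-c4ccccc4)nc3-c3ccc(F)cc3)nn2)cc1OC`, is the next member. Its difference from compound 2 is 3,4-dimethoxyphenyl in place of 4-(trifluoromethyl)phenyl on a saturated chain carbon bound to an aromatic nitrogen. For the measured compounds named here, no measured pair covers this particular exchange, so the only guide is the size of the step from compound 1 to compound 2, which was large. That step shows the benzyl substituent can move the number far in either direction; the dimethoxy pattern is a different kind of group from trifluoromethyl, and there is nothing to show it keeps the gain seen in compound 2. The expectation is therefore a step back towards the higher number of compound 1, of moderate size, a 5.3-fold higher number from compound 2 to compound 3 (0.72 log units; beyond the scatter), with wide uncertainty. Compound 3 is expected to give about 4000 nM, within a range of 1000 nM to 16000 nM.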

Compound 3, concentration for 50% growth inhibition: > 100000 nM
Compound 3: no number, only a limit (the forecaster's own chance of this, stated with the estimate: 10%); middle value at least 25-fold (1.39 log units) from the limit.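

Among these compounds, compounds 1 and 2 showed only that the group on the benzyl carbon can lower the number on this core, and compound 3 shows that it can also raise it sharply. In this assay, the exchange gives an at least 130-fold higher number from compound 2 to compound 3 (2.11 log units; beyond the scatter) and also an at least 6.9-fold higher number from compound 1 to compound 3 (0.84 log units; beyond the scatter) so 3,4-dimethoxyphenyl falls behind both 4-(trifluoromethyl)phenyl and 4-fluorophenyl at this place, which makes this position sensitive in both directions among the three compounds shown. Compound 3 has a limit of the assay and not an exact number, so both steps give only a minimum size: the limit of > 100000 nM in this assay, at which 1 of the 3 values shown sits.

The compounds shown leave open whether the loss needs both methoxy groups, and a benzyl group carrying a single methoxy would help to separate the two, while a benzyl group with a hydroxyl in place of each methoxy would test the oxygen substituents further. As far as these compounds go, it also remains open how far the gain of compound 2 extends to other groups on the benzyl ring, such as chloro, nitrile or a plain unsubstituted benzyl.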